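Propyl to isopropyl on a sulfur

A few compounds are considered here, and "the series" means these few. Any claim that something is new, unique, unknown or untested is made for them only; others in the source may bear on it.

In a functional assay on SH-SY5Y cells (Homo sapiens) for cytotoxicity, read by MTT assay, with a stated time of 72 h (a lower number here means a stronger inhibitor, a higher number a weaker inhibitor), compound 1 (`S=C=NCCCCSCc1ccccc1`) gives 20700 nM, compound 2 (`CC[S+]([O-])CCCCN=C=S`) gives 9810 nM and compound 3 (`CCC[S+]([O-])CCCCN=C=S`) gives 7660 nM. The number for compound 3 sits clearly under that of compound 1, but it cannot be told apart from that of compound 2. Compound 4 (`CC(C)[S+]([O-])CCCCN=C=S`) has the same atoms as compound 3, joined differently: isopropyl in place of propyl on a sulfur. Put simply, isopropyl stands in place of propyl on a sulfur. Among the compounds with values here, the one measured step that bears on this is a 1.3-fold lower number from compound 2 to compound 3 (0.11 log units; within the scatter), which lies within the scatter and also alters the group on the sulfur, so no step beyond the scatter is expected in this assay. Within the data shown here, no measured pair tests a branched group, so the expectation remains uncertain. The estimated step is a 1.0-fold higher number from compound 3 to compound 4 (0.02 log units; within the scatter). For compound 4 the expected value is 8000 nM, with an estimated range of 4500 nM to 14000 nM.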

Compound 4, half-maximal inhibitory concentration: 9420 nM
Estimate against measurement, compound 4: 1.2-fold (0.07 log units) below; the range from low to high includes it.
By their numbers in this assay, from the lowest: compounds 3, 4 and 2 (each within the scatter of the next); then compound 1.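

A branched group on the sulfur now has a measured result, and in this assay it cannot be told apart from the straight propyl chain (a 1.2-fold higher number from compound 3 to compound 4 (0.09 log units; within the scatter)). The second new step (a 1.0-fold lower number from compound 2 to compound 4 (0.02 log units; within the scatter)) adds a methyl in place of hydrogen on a saturated chain carbon bound to a saturated chain carbon and a sulfur, and it also stays within the scatter, so at this position neither change gives a difference that can be read. Nothing measured here accounts for this result.

Still open, as far as these compounds go, is whether a bulkier branched group such as tert-butyl, or a ring such as cyclohexyl, on the sulfur would give a step beyond the scatter. The same question stands for a longer chain on the sulfur, or for one carrying an amine or a carboxylic acid.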